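This account rests on a few compounds, and the source may have more. Where it says the series, first, only, none or still open, it means among the compounds named here.

Measured so far in a functional assay on KM12 cells (Homo sapiens) for inhibition, read by sulforhodamine B assay, with a stated time of 48 h; on this read-out higher numbers stand for weaker inhibition of growth and lower numbers for stronger inhibition of growth:
compound 1 `Nc1cc(N)c2nc(-c3ccccc3)c(Oc3ccc(Cl)c(Cl)c3)nc2c1` gives 6310 nM
compound 2 `Nc1cc(N)c2nc(-c3ccccc3)c(NCc3ccc(Cl)c(Cl)c3)nc2c1` gives 3390 nM
compound 3 `CCOC(=O)[C@H](CCC(=O)O)NC(=O)c1ccc(Sc2nc3cc(N)cc(N)c3nc2-c2ccccc2)cc1` gives 24000 nM

Among these three numbers compound 1 holds the second highest. Its nearest neighbour is compound 2, whose number lies within the usual scatter of compound 1, so the two cannot be told apart. Compound 3 sits furthest away, with a higher number beyond the scatter, meaning weaker inhibition of growth than compound 1.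

Compound 4 `Nc1cc(N)c2nc(-c3ccccc3)c(Oc3ccc(F)cc3)nc2c1` has not yet been measured. It differs from compound 1 in one place: 4-fluorophenyl in place of 3,4-dichlorophenyl on an oxygen on an aromatic ring. Among the compounds with values here, no measured pair shows this change, so its effect has to be guessed. A small step toward a higher number, that is weaker inhibition, is expected: a 1.6-fold higher number from compound 1 to compound 4 (0.20 log units; within the scatter). A result within the scatter would also be unsurprising. Compound 4 is therefore expected to give about 10000 nM, with a range from 3000 nM to 35000 nM.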

Compound 4, concentration for 50% growth inhibition: 14500 nM
Beside the measured number, compound 4's estimate is 1.5-fold (0.16 log units) below it, and the stated range covers the measured number.
By their numbers in this assay, from the lowest: compounds 2 and 1 (each within the scatter of the next); then compounds 4 and 3 (each within the scatter of the next).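

In this assay, 4-fluorophenyl in place of 3,4-dichlorophenyl on the oxygen gives a 2.3-fold higher number from compound 1 to compound 4 (0.36 log units; beyond the scatter), meaning weaker inhibition of growth. The earlier compounds shown here offered no pair differing in one place, and this pair shows that the group on this oxygen can move the result beyond the usual scatter, though only modestly. Nothing available explains this step. The change swaps both chlorines for one fluorine, so the compounds shown cannot say which part of it matters. A 4-chlorophenyl on the same oxygen would help to separate these parts.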